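Shifting the methoxy group on the benzyl arm

This account rests on a few compounds, and the source may have more. Where it says the series, first, only, none or still open, it means among the compounds named here.

Compound 1 `C=C(Br)C(=O)Nc1cccc(-c2cn3nc(Cc4cccc(OC)c4)sc3n2)c1` gives 2500 nM in a functional assay on HeLa cells (Homo sapiens) for inhibition, read by cell counting, with a stated time of 4 days; a higher number here means a weaker inhibitor, a lower number a stronger inhibitor.
Compound 2 `Nc1cccc(-c2cn3nc(Cc4ccccc4)sc3n2)c1` gives 24000 nM in this assay.
Compound 3 `COc1ccc(Cc2nn3cc(-c4cccc(N)c4)nc3s2)cc1` gives 191000 nM in this assay.

Compound 3 stands highest of the three numbers, beyond the scatter from both others. For the measured compounds named here, the one step leading to it, an 8.0-fold higher number from compound 2 to compound 3 (0.90 log units; beyond the scatter), was methoxy in place of hydrogen on an aromatic carbon. Compound 4 `COc1cccc(Cc2nn3cc(-c4cccc(N)c4)nc3s2)c1` differs from compound 3 in that (3-methoxyphenyl in place of 4-methoxyphenyl on a saturated chain carbon bound to an aromatic carbon). Going by the values given here, no measured step tests this change directly; compound 1 also carries 3-methoxyphenyl and gives a far lower number, but it differs in a second group as well. A modest fall is therefore expected in this assay, namely a 3.8-fold lower number from compound 3 to compound 4 (0.58 log units; beyond the scatter). Compound 4 is estimated at 50000 nM, with a range from 10000 nM to 250000 nM.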

Compound 4, half-maximal inhibitory concentration: 24000 nM
The estimate for compound 4 lay 2.1-fold (0.32 log units) above the measured number; low and high end bracket the measured number.
By their numbers in this assay, from the lowest: compound 1; then compounds 2 and 4 (each within the scatter of the next); then compound 3.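

In this assay, 3-methoxyphenyl in place of 4-methoxyphenyl on the benzyl arm gives an 8.0-fold lower number from compound 3 to compound 4 (0.90 log units; beyond the scatter), so the place of the methoxy matters here. The earlier loss on adding methoxy therefore holds only for 4-methoxyphenyl, since adding it as 3-methoxyphenyl gives no change at the digits printed from compound 2 to compound 4 (within the scatter) and leaves the number where it was. With 3-methoxyphenyl held constant, the acyl group can now be read alone: hydrogen in place of (1-bromoethenyl)carbonyl gives a 9.6-fold higher number from compound 1 to compound 4 (0.98 log units; beyond the scatter).

No evidence is available to explain these differences. Still open, from the compounds shown here alone, is how a hydroxy group or a chlorine would fare in place of the methoxy, and whether a plain acetyl group on the nitrogen would match the (1-bromoethenyl)carbonyl.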